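Sulfonyl aryl variation on the shared indazole-bearing core

This account rests on a few compounds, and the source may have more. Where it says the series, first, only, none or still open, it means among the compounds named here.

Measured so far in a functional assay on HL-60 cells (Homo sapiens) for antiproliferative activity, read by MTT assay, with a stated time of 72 h; on this read-out lower numbers stand for stronger inhibition and higher numbers for weaker inhibition:
- compound 1 `CN(C(=O)C(C)(C)C)c1ccc2[nH]c(-c3n[nH]c4ccccc34)cc2n1`: 4990 nM
- compound 2 `CN(C(=O)c1ccc(Br)cc1)c1ccc2[nH]c(-c3n[nH]c4ccccc34)cc2n1`: 1080 nM
- compound 3 `CN(c1ccc2[nH]c(-c3n[nH]c4ccccc34)cc2n1)S(=O)(=O)c1ccc(Cl)cc1`: 770 nM

Compound 3 gives the lowest number of the three, though its gap to compound 2 is within the scatter a 1.4-fold lower number from compound 2 to compound 3 (0.15 log units; within the scatter); only against compound 1 is it clearly separated a 6.5-fold lower number from compound 1 to compound 3 (0.81 log units; beyond the scatter). Compound 4 `CN(c1ccc2[nH]c(-c3n[nH]c4ccccc34)cc2n1)S(=O)(=O)c1cccc([N+](=O)[O-])c1` keeps the sulfonyl attachment and changes only the aryl group: 3-nitrophenyl in place of 4-chlorophenyl on a sulfonyl sulfur. Going by the values given here, no measured step changes an aryl substituent alone; the nearest, a 1.4-fold lower number from compound 2 to compound 3 (0.15 log units; within the scatter), swaps both linker and halogen without leaving the scatter, while a 4.6-fold lower number from compound 1 to compound 2 (0.66 log units; beyond the scatter) concerns tert-butyl against aryl. The expectation is therefore a step within the scatter in this assay, a 1.2-fold higher number from compound 3 to compound 4 (0.07 log units; within the scatter), in no firm direction. Compound 4 is estimated at 900 nM, with a range of 300 nM to 2700 nM.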

Compound 4, half-maximal inhibitory concentration: 3660 nM
Compound 4: the middle estimate sits 4.1-fold (0.61 log units) below what was measured; measured number above the stated range.
By their numbers in this assay, from the lowest: compounds 3 and 2 (each within the scatter of the next); then compounds 4 and 1 (each within the scatter of the next).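

In this assay the aryl group on the sulfonyl sulfur proves able to shift the read-out: a 4.8-fold higher number from compound 3 to compound 4 (0.68 log units; beyond the scatter) is the only step shown that changes that group alone, and it lies beyond the scatter. Keeping the sulfonamide nitrogen and sulfonyl attachment therefore does not by itself hold the number near that of compound 3. Nothing available accounts for this step.

The change from 4-chlorophenyl to 3-nitrophenyl alters the substituent and its ring position together, and these remain unseparated. Going by these compounds, whether an unsubstituted phenyl or an aminophenyl group on the sulfonyl sulfur would stay near compound 3 or compound 4 remains open.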